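Pyrrolidine for Dimethylamino on a Flavone Side Chain

A few compounds are considered here, and "the series" means these few. Any claim that something is new, unique, unknown or untested is made for them only; others in the source may bear on it.

Measured compounds:
compound 1, `COc1cc(OC)c2c(=O)cc(-c3ccc(OCC(O)CN4CCCC4)cc3)oc2c1`, 57%
compound 2, `COc1cc(OC)c2c(=O)cc(-c3ccc(OCC(O)CN(C)C)cc3)oc2c1`, 71%
compound 3, `COc1cc(OC)c2c(=O)cc(-c3ccc(NCCN(C)C)cc3)oc2c1`, 84%

The three compounds were tested in a functional assay (Homo sapiens) for antiproliferative activity, read by resazurin assay, with a stated time of 48 h, tested at 20 uM; a lower number here means a weaker effect, a higher number a stronger effect of the compound at the concentration tested. Compound 3 stands highest, with compound 2 nearest and compound 1 furthest, both gaps beyond the scatter. Compound 2 and compound 1 differ in one place, (pyrrolidin-1-yl in place of dimethylamino on a saturated chain carbon, two bonds along the chain from an oxygen on a saturated carbon), and the step was a number 14 percentage points lower from compound 2 to compound 1 (beyond the scatter). The cores of compound 2 and compound 3 differ as (2-(dimethylamino)ethyl)amino in place of 3-(dimethylamino)-2-hydroxypropoxy on an aromatic carbon, with the step of a number 13 percentage points higher from compound 2 to compound 3 (beyond the scatter); compound 1 to compound 3 combines both changes, a number 27 percentage points higher from compound 1 to compound 3 (beyond the scatter).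

Compound 4, `COc1cc(OC)c2c(=O)cc(-c3ccc(NCCN4CCCC4)cc3)oc2c1`, is not yet measured. It is made from compound 3 by pyrrolidin-1-yl in place of dimethylamino on a saturated chain carbon, two bonds along the chain from a nitrogen on an aromatic ring. This is the same kind of change as that from compound 2 to compound 1, though the place differs: there the carbon was two bonds along the chain from an oxygen on a saturated carbon, here it is two bonds along the chain from a nitrogen on an aromatic ring. Within the data shown here, compound 4 is expected to fall by a number 12 percentage points lower from compound 3 to compound 4 (beyond the scatter), a step resting on the single earlier instance a number 14 percentage points lower from compound 2 to compound 1 (beyond the scatter). Compound 4 is therefore estimated at 72%, between 58% and 84%.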

Compound 4, a percentage reported as inhibition, at one concentration (the size of the read-out at that concentration, not a potency): 80%
For compound 4 the middle estimate is 8 percentage points below the measured one, and the stated range covers the measured number.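

In this assay the exchange of dimethylamino for pyrrolidin-1-yl on the amino-linked chain gave (a number 4 percentage points lower from compound 3 to compound 4 (within the scatter)), and its two instances do not differ: the same change on two cores in this assay, a number 14 percentage points lower (beyond the scatter) from compound 2 to compound 1 and a number 4 percentage points lower (within the scatter) from compound 3 to compound 4, 10 percentage points apart, within the scatter of two such steps. The change therefore carries from one core to the other without a difference that can be told from the scatter, but two pairs cannot fix its size, and the step on the core of compound 3 cannot be told from the scatter on its own. With pyrrolidin-1-yl kept on both sides, the exchange of the hydroxypropoxy chain for the amino-linked chain gave (a number 23 percentage points higher from compound 1 to compound 4 (beyond the scatter)), while the step that alters both the chain and the amine gave (a number 9 percentage points higher from compound 2 to compound 4 (within the scatter)), so this series offers no sign that the amine exchange matters more than the choice of chain.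

As far as these compounds go, whether a piperidin-1-yl or morpholin-4-yl group would behave like pyrrolidin-1-yl remains open. So does the effect of a longer chain in place of the 2-(pyrrolidin-1-yl)ethyl link, and each read-out here is a single-concentration figure, not a potency.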